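Allyl to Ethyl on an Aryl Ether in Flavonoid Cytotoxicity

The compounds below may be only part of what the source reports. "The series", "measured", "known", "first", "only" and "open" are said of these compounds alone.

Compound 1 `COc1cc(C)cc2c1OC(c1ccccc1)CC2=O` in a functional assay on KB cells (Homo sapiens) for cytotoxicity (a higher number here means that more compound is needed for the effect, a lower number that less compound is needed), gives 26 ug/mL. Compound 2 `COc1ccccc1-c1cc(=O)c2ccc(OC)c(OC)c2o1` in this assay gives 4 ug/mL. Compound 3 `C=CCOc1ccc(-c2cc(=O)c3c(OC)c(OC)c(OC)c(OC)c3o2)cc1` in this assay gives 26 ug/mL.

Among these three, compound 3 stands level with compound 1 at the digits reported, the two of them sharing the highest number, so more of either is needed for the effect than of compound 2. The gap between compound 3 and compound 1 lies within the usual scatter of repeated measurements, while the gap to compound 2 is beyond it: compound 2 needs a clearly smaller amount.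

Compound 4 `CCOc1ccc(-c2cc(=O)c3c(OC)c(OC)c(OC)c(OC)c3o2)cc1` has not yet been measured. It differs from compound 3 in one place only: methyl in place of vinyl on a saturated chain carbon bound to an oxygen on an aromatic ring. The allyloxy group of compound 3 becomes an ethoxy group in compound 4, and everything else in the shared core is kept.

Among the measured compounds shown here, no pair of measured compounds shows a step of this kind, so there is nothing here to say that swapping allyloxy for ethoxy should move the number. The expectation is therefore a step of no change beyond the scatter in this assay from compound 3 to compound 4, no change at the digits printed from compound 3 to compound 4 (within the scatter). On that basis compound 4 is estimated at 26 ug/mL, within a range of 10 ug/mL to 65 ug/mL.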

Compound 4, concentration for half-maximal effect: 30 ug/mL
Compound 4: the middle estimate sits 1.2-fold (0.06 log units) below what was measured; low and high end bracket the measured number.
By their numbers in this assay, from the lowest: compound 2; then compounds 1, 3 and 4 (each within the scatter of the next).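

The swap of allyloxy for ethoxy gives a direct reading at this place, on a saturated chain carbon bound to an oxygen on an aromatic ring: in this assay, methyl in place of vinyl gives a 1.2-fold higher number from compound 3 to compound 4 (0.06 log units; within the scatter). The vinyl group and its double bond outside the aromatic rings can therefore be removed from this shared core without a change that can be told apart from the scatter, so in this pair the double bond makes no readable difference to the number. Nothing measured here offers an explanation for this outcome, so the pair records the size of the step and nothing of what lies behind it.

Still open, on these data alone, is whether this place responds to groups of a different kind, such as an amine or a carboxylic acid in place of the methyl, or to a longer chain in place of the ethyl. This is also a single pair on a single core, so it cannot say whether the same swap would leave the number unmoved on a different core.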